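A few compounds are considered here, and "the series" means these few. Any claim that something is new, unique, unknown or untested is made for them only; others in the source may bear on it.

In a functional assay on HCT-116 cells (Homo sapiens) for antiproliferative activity, read by MTT assay (on this read-out lower numbers stand for stronger inhibition and higher numbers for weaker inhibition), compound 1 `Cn1c(=O)c(=O)n(C2CCCC2)c2nc(N/N=C/c3ccccc3)ncc21` gives > 100000 nM, which is a limit of the assay and not a number. Two substituted analogues gave measured values: compound 2 `Cn1c(=O)c(=O)n(C2CCCC2)c2nc(N/N=C/c3ccc(F)cc3Br)ncc21` reads 8390 nM, and compound 3 `Cn1c(=O)c(=O)n(C2CCCC2)c2nc(N/N=C/c3cccc([N+](=O)[O-])c3)ncc21` reads 15200 nM. These two cannot be separated, since the gap between them, a 1.8-fold higher number from compound 2 to compound 3 (0.26 log units; within the scatter), is no more than ordinary scatter.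

Compound 4 `Cn1c(=O)c(=O)n(C2CCCC2)c2nc(N/N=C/c3ccc(OC(F)(F)F)cc3)ncc21` has not yet been measured. Its change is trifluoromethoxy in place of hydrogen on an aromatic carbon. The closest guides are an at least 11-fold lower number from compound 1 to compound 2 (1.07 log units; beyond the scatter), a large step, and an at least 6.5-fold lower number from compound 1 to compound 3 (0.81 log units; beyond the scatter), an at least modest one. Each places a substituent on the same aromatic ring, although neither uses this group, so the comparison is only rough. A lower number is therefore expected in this assay, beyond the scatter and of similar size to those two steps. The expected change is an at least 6.6-fold lower number from compound 1 to compound 4 (0.82 log units; beyond the scatter). For compound 4 the estimated value is 15000 nM, with an expected range of 5000 nM to 60000 nM.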

Compound 4, half-maximal inhibitory concentration: 6150 nM
The estimate for compound 4 lay 2.4-fold (0.39 log units) above the measured number, and the stated range covers the measured number.
By their numbers in this assay, from the lowest: compounds 4, 2 and 3 (each within the scatter of the next, the first and the last beyond it). At a limit, above all of these: compound 1.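

In this assay, trifluoromethoxy on an aromatic carbon, para to a large group, gives an at least 16-fold lower number from compound 1 to compound 4 (1.21 log units; beyond the scatter). The earlier steps shown here came from a nitro group and from the 2-bromo-4-fluorophenyl group, so this result adds that one group at this place on the ring, with no second substituent on that ring, is enough for a large step. Compound 1 stands at a limit and not at a number, so this step gives only a bound on the true change: the limit of > 100000 nM in this assay, at which 1 of the 4 values shown sits.

It remains open whether the step depends on trifluoromethoxy itself, since the compounds shown say nothing about an amine, a carboxylic acid or a methoxy group at the same place. They also leave open how much of the change comes from the fluorine atoms and how much from the oxygen that links them to the ring.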